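This account rests on a few compounds, and the source may have more. Where it says the series, first, only, none or still open, it means among the compounds named here.

Working notes on the series, read in an ADME assay on L6 cells (Rattus norvegicus) for cytotoxicity, read by resazurin assay, with a stated time of 70 h; on this read-out lower numbers stand for stronger inhibition and higher numbers for weaker inhibition. Compound 1 (`COc1cc(NC(C)CCCNC(=O)Nc2ccc(Cl)c(C(F)(F)F)c2)c2ncccc2c1`) gives "not determined" (no result reported), so it offers no number for comparison. Compound 2 (`COc1cc(NC(C)CCCNC(=O)NNC(=O)/C=C/c2ccccc2)c2ncccc2c1`) gives 13900 nM. Going by the values given here, compound 3 (`COc1ccc(/C=C/C(=O)NNC(=O)NCCCC(C)Nc2cc(OC)cc3cccnc23)cc1`) gives 3600 nM, which is the lower of the two numbers available, and compound 2 is its only numerical neighbour.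

Compound 4 (`COc1cc(NC(C)CCCNC(=O)NNC(=O)/C=C/c2ccc(Cl)cc2)c2ncccc2c1`) has not yet been measured. Its difference from compound 3 is chloro in place of methoxy on an aromatic carbon. In other words, 4-methoxyphenyl becomes 4-chlorophenyl, with chloro in place of methoxy on an aromatic carbon.

Among the compounds with values here, one measured step bears on this change: a 3.9-fold lower number from compound 2 to compound 3 (0.59 log units; beyond the scatter). It is modest, lies beyond the scatter and involves methoxy in place of hydrogen on an aromatic carbon. Within the data shown here, no measured pair compares chloro with methoxy, so this step gives only a rough scale and no direction. Compound 4 keeps a group at that place, so a return to the level of compound 2 is not the main expectation. The expected step is small, a 1.3-fold higher number from compound 3 to compound 4 (0.10 log units; within the scatter), and no shift beyond the scatter is anticipated in this assay. The estimated value for compound 4 is 4500 nM, with an expected range of 1700 nM to 12000 nM.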

Compound 4, half-maximal inhibitory concentration: 7300 nM
For compound 4 the middle estimate is 1.6-fold (0.21 log units) below the measured one; low and high end bracket the measured number.
By their numbers in this assay, from the lowest: compound 3; then compounds 4 and 2 (each within the scatter of the next).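

In this assay, going by these compounds alone, the exchange of methoxy for chloro, on an aromatic carbon para to a large group, gives a 2.0-fold higher number from compound 3 to compound 4 (0.31 log units; beyond the scatter) as the first direct comparison of two substituents at this place, and the step lies only just beyond the scatter. Chloro in place of hydrogen gives a 1.9-fold lower number from compound 2 to compound 4 (0.28 log units; within the scatter) and stays within the scatter, whereas methoxy in place of hydrogen gives a 3.9-fold lower number from compound 2 to compound 3 (0.59 log units; beyond the scatter) and lies beyond it. Among these three compounds, then, the presence of a substituent at this place is not enough for a step beyond the scatter from the unsubstituted compound: methoxy gives one and chloro does not, and no available measurement offers a reason for this difference.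

The compounds shown leave open how other groups at this place would read in this assay, for example a hydroxyl, an amine, a carboxylic acid or a longer alkoxy chain. They also leave open whether the separation between methoxy and chloro would persist with a different linker to the shared core, since all three comparisons rest on a single linker and a single cell line.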